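The source may hold more compounds than are shown below. What is called first, only, known or untested is meant among the compounds shown, and "the series" means these compounds.

Of the compounds shown here, three sharing one core have been measured in an assay on membranes from HeLa cells for displacement of a labelled ligand from adenosine receptor A3 (Homo sapiens), read by scintillation counting, with a stated time of 180 min, tested at 1 uM; on this read-out higher numbers stand for more inhibition at the one concentration tested (going by the name of the read-out) and lower numbers for less inhibition. Compound 1 `CCCOC(=O)C1=C(C)NC(=O)NC1c1ccco1` gives 3%, and compound 2 `CC1=C(C(=O)OC(C)(C)C)C(c2ccoc2)NC(=O)N1` gives 2%; these two numbers lie within the usual scatter of each other. Compound 3 `CC1=C(C(=O)CC(C)C)C(c2ccco2)NC(=O)N1` gives 31%, the highest of the three, standing well beyond the scatter above both others. Within the data shown here, the only single-point change among the measured compounds runs from compound 1 to compound 3, isobutyl in place of propoxy on a carbonyl carbon, and it raises the read-out by a number 28 percentage points higher from compound 1 to compound 3 (beyond the scatter).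

Compound 4 `CC1=C(C(=O)CC(C)C)C(c2ccoc2)NC(=O)N1` has not yet been measured. It differs from compound 3 in one place: furan-3-yl in place of furan-2-yl on a saturated ring carbon. Among the measured compounds shown here, no measured pair isolates this change. Compound 1 and compound 2 carry furan-2-yl and furan-3-yl, but they also differ in their ester groups, so their two values say nothing clean about the furan alone. For the measured compounds named here, the one measured step concerns the carbonyl substituent and does not bear on the furan. With nothing pointing in either direction, the change is expected to give a number 5 percentage points lower from compound 3 to compound 4 (within the scatter), which is no movement beyond the scatter. Compound 4 is therefore estimated at 26%, most likely between 6% and 46%.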

Compound 4, a percentage reported as inhibition, at one concentration (the size of the read-out at that concentration, not a potency): 18%
The estimate for compound 4 lay 8 percentage points above the measured number; the measured number falls inside the stated range.
By their numbers in this assay, from the lowest: compounds 2 and 1 (each within the scatter of the next); then compound 4; then compound 3.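

Furan-3-yl in place of furan-2-yl on the saturated ring carbon gives a number 13 percentage points lower from compound 3 to compound 4 (beyond the scatter) in this assay, the first clean reading of this change, since the isobutylcarbonyl group stays fixed and the two groups hold the same atoms, joined differently; at this position, then, the point of attachment of the furan matters. Isobutyl in place of tert-butoxy on the carbonyl carbon gives a number 16 percentage points higher from compound 2 to compound 4 (beyond the scatter) with furan-3-yl present, so the rise seen earlier with furan-2-yl, where isobutyl replaced propoxy, also appears with the other furan, although the two steps start from different esters. Nothing measured on these compounds accounts for either step.

The compounds shown leave open how a ring other than furan would behave on this carbon, for instance a thiophene or a phenyl ring, and whether either furan would keep its place in the order with a different carbonyl substituent. They also leave open what a longer chain or an amine would do in place of isobutyl on the carbonyl carbon.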